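Sulfonyl substituent swap: ethyl analogue of compound 3

The source may report more compounds than this note shows. Statements on the series, on what has been measured and on what is new or still open speak of the compounds shown alone.

The three measured compounds share one core and differ only at a sulfonyl sulfur: compound 1 `Cc1ccc(S(=O)(=O)N(C)CCN(C)C)cc1C#Cc1cc(Cl)ccc1OCC(=O)O`, compound 2 `Cc1ccc(S(C)(=O)=O)cc1C#Cc1cc(Cl)ccc1OCC(=O)O` and compound 3 `Cc1ccc(S(=O)(=O)N(C)C)cc1C#Cc1cc(Cl)ccc1OCC(=O)O`. In an assay on CHO cells for displacement of a labelled ligand from prostaglandin D2 receptor 2 (Homo sapiens), read by scintillation counting (on this read-out lower numbers stand for stronger inhibition and higher numbers for weaker inhibition), compound 1 gives 369 nM, compound 2 gives 5 nM and compound 3 gives 5 nM. Compound 3 stands level with compound 2 at the digits shown, the two together the lowest numbers of the set; the gap to the remaining member is a 74-fold lower number from compound 1 to compound 3 (1.87 log units; beyond the scatter).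

Compound 4 `CCS(=O)(=O)c1ccc(C)c(C#Cc2cc(Cl)ccc2OCC(=O)O)c1` is the next analogue. ethyl in place of dimethylamino on a sulfonyl sulfur Two kinds of measured step bear on this change. The direct comparison is no change at the digits printed from compound 2 to compound 3 (within the scatter), a swap of one small group for another on the same sulfur with no effect beyond the scatter. The large steps, a 74-fold lower number from compound 1 to compound 2 (1.87 log units; beyond the scatter) and a 74-fold lower number from compound 1 to compound 3 (1.87 log units; beyond the scatter), both involve loss of the longer chain carried by compound 1 and say nothing about swaps among small groups. Ethyl falls between methyl and dimethylamino in what is counted, so no step beyond the scatter is expected: a 1.2-fold higher number from compound 3 to compound 4 (0.08 log units; within the scatter). Compound 4 is accordingly estimated at 6 nM, within 2 nM to 20 nM.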

Compound 4, inhibition constant: 8.6 nM
Compound 4: the middle estimate sits 1.4-fold (0.16 log units) below what was measured; measured number inside the range.
By their numbers in this assay, from the lowest: compounds 2, 3 and 4 (each within the scatter of the next); then compound 1.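

In this assay, a third small group on the sulfonyl sulfur reads like the first two: a 1.7-fold higher number from compound 3 to compound 4 (0.24 log units; within the scatter) and a 1.7-fold higher number from compound 2 to compound 4 (0.24 log units; within the scatter), so neither replacing dimethylamino with ethyl nor adding a methyl to the saturated chain carbon bound to the sulfonyl sulfur moves the number beyond the scatter. Among the compounds shown here, with ethyl in place of (2-(dimethylamino)ethyl)(methyl)amino, the large gap seen with methyl and dimethylamino appears again, a 43-fold lower number from compound 1 to compound 4 (1.63 log units; beyond the scatter), which leaves compound 1 as the only member of the set standing apart. No evidence at hand bears on the cause of either the flat steps among the small groups or the large steps from compound 1.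

On these data alone, it remains open whether the large steps from compound 1 go with the amine in its chain or with the chain's length, and a butyl chain on the sulfonyl sulfur would help separate the two. As far as these compounds go, how far the flat behaviour extends is also open, for example to a hydroxyethyl chain, a cyclopropyl ring or a plain amino group on the same sulfur in this assay.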